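The source may report more compounds than this note shows. Statements on the series, on what has been measured and on what is new or still open speak of the compounds shown alone.

Compound 1 `Cc1ccc(NC(=O)c2ccc(/N=N\c3c[nH]c4ccccc34)cc2)c(C)c1` and compound 2 `O=C(Nc1ccccc1F)c1ccc(/N=N\c2c[nH]c3ccccc23)cc1` share one core and differ only in the group on an amide-type nitrogen. In a functional assay on MCF7 cells (Homo sapiens) for inhibition, read by MTT assay, with a stated time of 72 h (on this read-out higher numbers stand for weaker inhibition and lower numbers for stronger inhibition), compound 1 gives 87000 nM, and in this assay compound 2 gives 83800 nM; the step of a 1.0-fold lower number from compound 1 to compound 2 (0.02 log units; within the scatter) leaves both numbers within the scatter of each other, so neither stands apart. Compound 3 `O=C(Nc1ccc([N+](=O)[O-])cc1)c1ccc(/N=N\c2c[nH]c3ccccc23)cc1` changes that same place again: 4-nitrophenyl in place of 2-fluorophenyl on an amide-type nitrogen. Going by the values given here, the only measured step at this place, a 1.0-fold lower number from compound 1 to compound 2 (0.02 log units; within the scatter), lay within the scatter, so no shift beyond the scatter is expected in this assay. Compound 3 is therefore estimated at 80000 nM, with a range from 30000 nM to 200000 nM. This estimate means an expected step of a 1.0-fold lower number from compound 2 to compound 3 (0.02 log units; within the scatter).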

Compound 3, half-maximal inhibitory concentration: 54500 nM
Compound 3: middle estimate off by 1.5-fold (0.17 log units), on the high side; the range from low to high includes it.
By their numbers in this assay, from the lowest: compounds 3, 2 and 1 (each within the scatter of the next).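

In this assay, going by these compounds alone, 4-nitrophenyl brings two hydrogen-bond acceptors that 2-fluorophenyl lacks, yet the result is a 1.5-fold lower number from compound 2 to compound 3 (0.19 log units; within the scatter) and a 1.6-fold lower number from compound 1 to compound 3 (0.20 log units; within the scatter) in the comparison with the first compound of the series. A third substituted phenyl group on this amide-type nitrogen therefore still does not stand apart from the others. No supporting measurement bears on this result. The shown compounds all carry a substituted phenyl ring here, so whether an amine, a carboxylic acid or a longer carbon chain in this place would give a step beyond the scatter stays open.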